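Fluoro for Hydrogen in a Series with Low Numbers

A few compounds are considered here, and "the series" means these few. Any claim that something is new, unique, unknown or untested is made for them only; others in the source may bear on it.

Measured so far in an assay on isolated protein for inhibition of Rho-associated protein kinase 1 (Homo sapiens), tested at 30 uM; a lower number here means less inhibition, a higher number more inhibition at the concentration tested (going by the name of the read-out):
compound 1, `Clc1ncnc2c1ncn2Cc1ccccc1`, gives 3%
compound 2, `Fc1ccc(Cn2cnc3c(Cl)ncnc32)cc1`, gives 0%
compound 3, `Fc1ccc(Cn2cnc3c(Sc4ccccc4)ncnc32)cc1`, gives 2%

All three measured compounds sit near the bottom of the scale in this assay. The change from compound 1 to compound 2 is fluoro in place of hydrogen on an aromatic carbon, and it made a step of a number 3 percentage points lower from compound 1 to compound 2 (within the scatter). From compound 2 to compound 3 the step was a number 2 percentage points higher from compound 2 to compound 3 (within the scatter). How compound 3 differs from compound 1 is not broken down here.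

Compound 4, `Fc1ccc(Cn2cnc3c(Sc4ccc(F)cc4)ncnc32)cc1`, has not yet been measured. It differs from compound 3 by fluoro in place of hydrogen on an aromatic carbon, and the place of the change reads the same word for word as that from compound 1 to compound 2, so it is the same change, occurring twice among these compounds. Since the earlier such step was a number 3 percentage points lower from compound 1 to compound 2 (within the scatter), compound 4 is expected to stay at the same low level, with an estimated step of no change at the digits printed from compound 3 to compound 4 (within the scatter). The estimate for compound 4 is therefore 2%, between -6% and 10%.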

Compound 4, a percentage reported as inhibition, at one concentration (the size of the read-out at that concentration, not a potency): 0%
The estimate for compound 4 lay 2 percentage points above the measured number; the measured number falls inside the stated range.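

In this assay, fluoro in place of hydrogen gave a number 2 percentage points lower from compound 3 to compound 4 (within the scatter), and (4-fluorophenyl)sulfanyl in place of chloro gave no change at the digits printed from compound 2 to compound 4 (within the scatter). Fluoro for hydrogen thus read alike on the two cores: the same change on two cores in this assay, a number 3 percentage points lower (within the scatter) from compound 1 to compound 2 and a number 2 percentage points lower (within the scatter) from compound 3 to compound 4, 1 percentage points apart, within the scatter of two such steps This does not show how the change would behave on a compound with a clearly higher number, as all four numbers sit near the bottom of the scale, where a lower number has little room to appear.

The compounds shown leave open whether any group on the shared core would raise the number in this assay, for example an amine in place of the chloro or a carboxylic acid on the phenylsulfanyl group. They also leave open whether a methoxy group in place of the fluoro, or a longer chain in place of the benzyl group, would read any differently from the compounds at hand.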